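The source may report more compounds than this note shows. Statements on the series, on what has been measured and on what is new or still open speak of the compounds shown alone.

In an ADME assay on liver (Homo sapiens) for metabolic stability, read by LC-MS, using microsomes and NADPH (a lower number here means that less of the compound is left, a higher number that more of the compound is left), the measured compounds read:
compound 1 `CCCN(Cc1ccc(OCCN2C(=O)CCC2=O)c(C)c1)C(CC(=O)O)c1ccc(Cl)cc1` gives 85%
compound 2 `CCN(Cc1ccc(OCCN2C(=O)CCC2=O)c(C)c1)C(CC(=O)O)c1ccc(Cl)cc1` gives 100%
compound 3 `Cc1cc(CN(CC2CC2)C(CC(=O)O)c2ccc(Cl)cc2)ccc1OCCN1C(=O)CCC1=O` gives 96%

Compound 3 is level with compound 2 within the scatter, as a number 4 percentage points lower from compound 2 to compound 3 (within the scatter) shows. It stands clear of compound 1, with a number 11 percentage points higher from compound 1 to compound 3 (beyond the scatter).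

The next compound is compound 4 `CCCCN(Cc1ccc(OCCN2C(=O)CCC2=O)c(C)c1)C(CC(=O)O)c1ccc(Cl)cc1`, and its change from compound 3 is propyl in place of cyclopropyl on a saturated chain carbon bound to an amine nitrogen. On the saturated chain carbon bound to an amine nitrogen, compound 2 carries methyl, compound 1 ethyl and compound 3 cyclopropyl.

Going by the values given here, two measured steps bear most directly on compound 4. Extending the open chain gave the reverse of a number 15 percentage points higher from compound 1 to compound 2 (beyond the scatter), and closing to cyclopropyl from ethyl gave a number 11 percentage points higher from compound 1 to compound 3 (beyond the scatter). Both suggest that open chains beyond methyl may read lower in this assay, but compound 3 goes against any simple trend with group size. Among the compounds with values here, no measured pair exchanges a ring for an open chain of equal count, so the expectation remains loose.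

The expected change is a number 18 percentage points lower from compound 3 to compound 4 (beyond the scatter), a modest fall. Compound 4 is estimated at 78%, with an expected range from 62% to 92%.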

Compound 4, percent of the compound remaining: 83%
Compound 4: middle estimate off by 5 percentage points, on the low side; low and high end bracket the measured number.
By their numbers in this assay, from the lowest: compounds 4 and 1 (each within the scatter of the next); then compounds 3 and 2 (each within the scatter of the next).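

In this assay, the ring and the open chain of equal carbon count now stand directly side by side on the saturated chain carbon bound to an amine nitrogen, and a number 13 percentage points lower from compound 3 to compound 4 (beyond the scatter) shows that cyclopropyl and propyl are not interchangeable at this position. Across the open chains, methyl in compound 2 separates clearly from propyl, with a number 17 percentage points lower from compound 2 to compound 4 (beyond the scatter), yet ethyl and propyl are level, with a number 2 percentage points lower from compound 1 to compound 4 (within the scatter), so among compounds 1, 2 and 4 the reading does not keep falling with each added carbon, and compound 3 goes against any simple trend with group size. No evidence given here accounts for the difference between the ring and the open chain.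

As far as these compounds go, whether the level reading of ethyl and propyl persists with a longer chain at this position remains open. Also open, from the compounds shown here alone, is whether a branched isopropyl group or a larger cyclobutyl ring would read with the open chains or with cyclopropyl.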